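The source may hold more compounds than are shown below. What is called first, only, known or untested is meant among the compounds shown, and "the series" means these compounds.

Of the three compounds already measured, two give only a limit and one gives a number. Compound 1 `CC(=O)O[C@H]1C=CC(=O)O[C@H]1[C@H]1OC(=O)O[C@@H]1c1ccccc1` is tested in a functional assay on HL-60 cells (Homo sapiens) for cytotoxicity, read by MTT assay, with a stated time of 48 h (a lower number here means a stronger inhibitor, a higher number a weaker inhibitor), and yields only a limit there, > 40000 nM. Compound 3 `CC(=O)O[C@H]1C=CC(=O)O[C@@H]1[C@@H](O)[C@@H](Nc1ccccc1)c1ccccc1` likewise reaches only a limit in this assay, > 40000 nM. For the measured compounds named here, compound 2 `CC(=O)O[C@H]1C=CC(=O)O[C@@H]1c1nc(/C=C/c2ccccc2)oc1-c1ccccc1` is the exception: in this assay compound 2 gives 5890 nM, the sole actual number in the set. The remaining values sit at the limit of > 40000 nM in this assay, at which 2 of the 3 values shown sit, so compound 2 is the only point from which a comparison can start.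

Compound 4 `C/C=C\c1nc([C@H]2OC(=O)C=C[C@@H]2OC(C)=O)c(-c2ccccc2)o1` is the untested partner of compound 2. The two differ in one place: prop-1-en-1-yl in place of 2-phenylethenyl on an aromatic carbon. Going by the values given here, no pair of measured compounds shows what such a swap does in this assay, so the size of the step is a guess rather than a reading from data. The expected step from compound 2 to compound 4 is a 2.0-fold higher number from compound 2 to compound 4 (0.31 log units; beyond the scatter), a modest loss. Compound 4 is therefore expected to show about 12000 nM, within a range from 4000 nM to 40000 nM.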

Compound 4, half-maximal inhibitory concentration: > 40000 nM
Compound 4: only a limit was reported (the forecaster's own chance of this, stated with the estimate: 30%); at least 3.3-fold (0.52 log units) between middle value and limit.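

Swapping 2-phenylethenyl for prop-1-en-1-yl on this aromatic carbon removes the six-membered aromatic ring of carbon only but keeps a double bond outside aromatic rings, and in this assay it gives an at least 6.7-fold higher number from compound 2 to compound 4 (0.83 log units; beyond the scatter). For the compounds shown here, this is the first measured step in the set, and it shows that the change at this position is not neutral: the smaller group does not keep the measurable activity seen with the larger one. Compound 4 gives only a limit, > 40000 nM, so the step has a lower bound but no upper one, and compound 4 joins the other compounds at that limit: the limit of > 40000 nM in this assay, at which 3 of the 4 values shown sit.

The compounds shown leave open whether the loss follows from removing the phenyl ring or from shortening the group, since the two groups differ in both respects. They also leave open how a saturated 2-phenylethyl chain, or a 2-phenylethenyl group carrying a methoxy group or an amine on its phenyl ring, would behave in this assay.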